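The source may report more compounds than this note shows. Statements on the series, on what has been measured and on what is new or still open speak of the compounds shown alone.

In an assay on isolated protein for inhibition of Fatty-acid amide hydrolase 1 (Rattus norvegicus) (a higher number here means a weaker inhibitor, a lower number a stronger inhibitor), compound 3 `CC(=O)c1coc(C(=O)CCCCCCc2ccccc2)n1` gives 2 nM, the lowest of the three numbers recorded. Compound 1 `Cc1coc(C(=O)CCCCCCc2ccccc2)n1` gives 520 nM and compound 2 `O=Cc1coc(C(=O)CCCCCCc2ccccc2)n1` gives 55 nM in this assay, so compound 3 sits well apart from both: a 260-fold lower number from compound 1 to compound 3 (2.41 log units; beyond the scatter) and a 28-fold lower number from compound 2 to compound 3 (1.44 log units; beyond the scatter), while a 9.5-fold lower number from compound 1 to compound 2 (0.98 log units; beyond the scatter). Compound 4 `O=C(CCCCCCc1ccccc1)c1nc(-c2ccccn2)co1` differs from compound 3 in one place: pyridin-2-yl in place of acetyl on an aromatic carbon. Within the data shown here, none of the measured steps exchanges the acetyl for an aromatic ring; each of them only builds a carbonyl up from the methyl of compound 1. Among the measured compounds shown here, the group that enters carries one hydrogen-bond acceptor, as does the one that leaves, so the change has no measured counterpart. On that basis, compound 4 is expected to stay near compound 3, with a step of a 2.5-fold higher number from compound 3 to compound 4 (0.40 log units; beyond the scatter) that could fall within the scatter. In this assay compound 4 is therefore estimated at 5 nM, in a range from 1.5 nM to 25 nM.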

Compound 4, inhibition constant: 1.9 nM
Beside the measured number, compound 4's estimate is 2.6-fold (0.42 log units) above it, within the range that was stated.
By their numbers in this assay, from the lowest: compounds 4 and 3 (each within the scatter of the next); then compound 2; then compound 1.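

In this assay, among these compounds, the aromatic carbon next to the ring nitrogen accepts pyridin-2-yl in place of acetyl with a 1.1-fold lower number from compound 3 to compound 4 (0.02 log units; within the scatter) and no change beyond the scatter, so a carbonyl on this carbon is not needed for a number at this level, something the earlier compounds, which all carried either methyl or a carbonyl group there, could not show. The ring also keeps the large distance from the smaller groups, with a 29-fold lower number from compound 2 to compound 4 (1.46 log units; beyond the scatter) and a 270-fold lower number from compound 1 to compound 4 (2.44 log units; beyond the scatter) as the two steps. Nothing available here accounts for why pyridin-2-yl and acetyl read alike.

Going by these compounds, whether the ring nitrogen of pyridin-2-yl matters stays open, and a phenyl ring or a pyridin-3-yl group on this carbon would be needed to tell. On these data alone, how a carboxylic acid or an amide would read at this position also remains open.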